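The source may hold more compounds than are shown below. What is called first, only, known or untested is meant among the compounds shown, and "the series" means these compounds.

Compound 1, `Cc1cc(NC(=O)Nc2ccccc2C(F)(F)F)c2ccccc2n1`, gives only a limit in an ADME assay on Raji cells (Homo sapiens) for cytotoxicity, with a stated time of 72 h; a lower number here means that less compound is needed, a higher number that more compound is needed for the effect: > 25000 nM.
Compound 2, `Cc1ccc(NC(=O)Nc2cc(C)nc3ccccc23)cc1`, gives only a limit in this assay: > 25000 nM.
Compound 3, `Cc1cc(NC(=O)Nc2ccccc2F)c2ccccc2n1`, gives only a limit in this assay: > 25000 nM.

Compound 3 therefore stands nowhere on a readable scale: it sits at the limit of > 25000 nM in this assay, at which 3 of the 3 values shown sit. The two steps that lead to it, a step that the two limits leave unreadable from compound 1 to compound 3 and a step that the two limits leave unreadable from compound 2 to compound 3, are both unreadable, since a limit meets a limit in each case. The next change, (methylsulfanyl in place of fluoro on an aromatic carbon), gives compound 4, `CSc1ccccc1NC(=O)Nc1cc(C)nc2ccccc12`. Going by the values given here, no measured step bears readably on this change, so no step beyond the scatter can be expected in either direction in this assay. Compound 4 is expected to remain at the limit as well, with an estimate of 30000 nM, ranging from 10000 nM to 100000 nM, an expected step that the limit leaves unreadable from compound 3 to compound 4.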

Compound 4, half-maximal effective concentration: > 25000 nM
Compound 4: a limit, no number; the forecaster's own chance of this, stated with the estimate: 85%; the middle value is on the limit's open side.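

Compound 4 also gives only a limit in this assay, so its steps from compound 1 and compound 3 cannot be read. The compounds shown leave open whether any of these changes shifts the read-out at all: the limit of > 25000 nM in this assay, at which 4 of the 4 values shown sit.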